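Chloro for fluoro on the urea aryl, two triazole cores

A few compounds are considered here, and "the series" means these few. Any claim that something is new, unique, unknown or untested is made for them only; others in the source may bear on it.

Compound 1 `CN(C)CCn1cnnc1-c1cc(Oc2ccc(NC(=O)Nc3ccc(F)c(F)c3)cc2F)ccn1` gives 17.6% in an assay on isolated protein for inhibition of proto-oncogene tyrosine-protein kinase receptor Ret (Homo sapiens), read by mobility shift assay, with a stated time of 1 h, tested at 10 uM; a lower number here means less inhibition, a higher number more inhibition at the concentration tested (going by the name of the read-out). Compound 2 `CN(C)CCn1cnnc1-c1cc(Oc2ccc(NC(=O)Nc3ccc(F)c(Cl)c3)cc2F)ccn1` differs from it by chloro in place of fluoro on an aromatic carbon and in this assay compound 2 gives 63.3%, a large gain: a number 45.7 percentage points higher from compound 1 to compound 2 (beyond the scatter). Compound 3 `CCN(CC)CCn1cnnc1-c1cc(Oc2ccc(NC(=O)Nc3ccc(F)c(F)c3)cc2F)ccn1` carries a different core, (diethylamino in place of dimethylamino on a saturated chain carbon, two bonds along the chain from an aromatic nitrogen), and in this assay compound 3 gives 7.1%, a modest loss: a number 10.5 percentage points lower from compound 1 to compound 3 (beyond the scatter). Compound 4 `CCN(CC)CCn1cnnc1-c1cc(Oc2ccc(NC(=O)Nc3ccc(F)c(Cl)c3)cc2F)ccn1` is not yet measured; it differs from compound 3 by chloro in place of fluoro on an aromatic carbon, the same change as that between compound 1 and compound 2, at the same place. For compound 4 the expected step is a number 40.9 percentage points higher from compound 3 to compound 4 (beyond the scatter), because the same change gave a number 45.7 percentage points higher from compound 1 to compound 2 (beyond the scatter), tempered because compound 3 starts lower at 7.1%. Compound 4 is estimated at 48%, expected between 25% and 72%.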

Compound 4, a percentage reported as inhibition, at one concentration (the size of the read-out at that concentration, not a potency): 1.9%
Compound 4: the middle estimate sits 46.1 percentage points above what was measured; measured number below the stated range.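

In this assay, chloro in place of fluoro does not carry over from the dimethylamino compounds to the diethylamino compounds, where the result is a number 5.2 percentage points lower from compound 3 to compound 4 (within the scatter); the two steps differ: the same change on two cores in this assay, a number 45.7 percentage points higher (beyond the scatter) from compound 1 to compound 2 and a number 5.2 percentage points lower (within the scatter) from compound 3 to compound 4, 50.9 percentage points apart, beyond the scatter of two such steps. Seen from the amine end, diethylamino in place of dimethylamino gives a number 61.4 percentage points lower from compound 2 to compound 4 (beyond the scatter), so the two changes do not add up across these four compounds: the same change on two cores in this assay, a number 10.5 percentage points lower (beyond the scatter) from compound 1 to compound 3 and a number 61.4 percentage points lower (beyond the scatter) from compound 2 to compound 4, 50.9 percentage points apart, beyond the scatter of two such steps. This rests on two pairs read at a single concentration, so it shows a dependence on the amine within this set, not a rule for the series, and it gives neither potency nor a cause.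

On these data alone, whether a cyclic amine such as pyrrolidine or morpholine on the same chain would keep the gain from chloro stays open. So does the behaviour of bromo at the same place on the urea aryl.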